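From chloro to tert-butyl on a shared core

This account rests on a few compounds, and the source may have more. Where it says the series, first, only, none or still open, it means among the compounds named here.

Of the compounds shown here, three built on one shared core have been tested in an ADME assay on CHO cells (Cricetulus griseus) for inhibition, read by MTT assay; on this read-out higher numbers stand for weaker inhibition and lower numbers for stronger inhibition. Compound 1 `CC(C)(C)NCc1cc(Cl)cc(Nc2nc3ccccc3[nH]2)c1O` gives in this assay > 50000 nM, which is a limit of the assay rather than a number. Compound 2 `CCN(CC)Cc1ccc(Nc2nc3ccccc3[nH]2)cc1O` gives in this assay > 50000 nM, again a limit. Compound 3 `CCN(CC)Cc1cccc(Nc2nc3ccccc3[nH]2)c1O` gives in this assay > 50000 nM, also a limit. All three values therefore sit at the limit of > 50000 nM in this assay, at which 3 of the 3 values shown sit, so compound 1 stands level with the others, and no order among them can be read from these numbers.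

Compound 4 `CC(C)(C)NCc1cc(C(C)(C)C)cc(Nc2nc3ccccc3[nH]2)c1O` has not yet been measured. It differs from compound 1 in one place: tert-butyl in place of chloro on an aromatic carbon. Within the data shown here, because compound 1 shows only the limit > 50000 nM, there is no measured step on which to size the change. Compound 4 is expected to stay near that limit, so the step from compound 1 to compound 4 is estimated as a step that the limit leaves unreadable from compound 1 to compound 4, nothing beyond the scatter. Compound 4 is estimated to give 60000 nM, within a range from 20000 nM to 200000 nM.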

Compound 4, half-maximal inhibitory concentration: 30500 nM
Estimate against measurement, compound 4: 2.0-fold (0.29 log units) above; the measured number falls inside the stated range.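

In this assay, among these compounds, compound 4 gives 30500 nM, the first value on this shared core that is a number rather than a limit of the assay. Compound 1 gives > 50000 nM, which is a limit, so the swap of chloro for tert-butyl at this position, para to a hydroxy group, can be sized only as a floor. That floor is an at least 1.6-fold lower number from compound 1 to compound 4 (0.21 log units; that floor lies within the scatter), so the change is not shown to exceed ordinary repeat scatter, and most values on this read-out still sit at one ceiling: the limit of > 50000 nM in this assay, at which 3 of the 4 values shown sit.

On these data alone, how a methyl, a methoxy or a carboxylic acid at this position would read in this assay remains open. As far as these compounds go, the true size of the step also remains open, as does how a plain hydrogen there would compare.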